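The source may hold more compounds than are shown below. What is called first, only, known or untested is meant among the compounds shown, and "the series" means these compounds.

Measured so far in a functional assay on ECa-109 cells (Homo sapiens) for antiproliferative activity, read by MTT assay, with a stated time of 72 h; a higher number here means a weaker inhibitor, a lower number a stronger inhibitor: compound 1 `CCCSc1nc(N/N=C/c2ccc(Cl)cc2)c2nnn(Cc3ccccc3)c2n1`, compound 2 `CCCSc1nc(N/N=C/c2cc(OC)c(OC)c(OC)c2)c2nnn(Cc3ccccc3)c2n1`, compound 3 `CCCSc1nc(N/N=C(\C)c2ccccc2O)c2nnn(Cc3ccccc3)c2n1`. Compound 1 gives only a limit, > 64000 nM. Compound 2 gives 4060 nM. Compound 3 gives 11100 nM.

Compound 1 therefore has no number of its own in this assay, only the limit (the limit of > 64000 nM in this assay, at which 1 of the 3 values shown sits); nothing can be said about where it stands relative to the others beyond that.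

Compound 4 `CCCSc1nc(N/N=C/c2c(O)ccc3ccccc23)c2nnn(Cc3ccccc3)c2n1` is not yet measured. Against compound 1 the change is 2-hydroxynaphthalen-1-yl in place of 4-chlorophenyl on a carbon with a double bond to nitrogen. Going by the values given here, the one measured step that bears on it is an at least 5.7-fold lower number from compound 1 to compound 3 (0.76 log units; beyond the scatter), where a hydroxy-bearing aryl group likewise replaced the 4-chlorophenyl and the number fell out of the limit into a measurable range. Compound 2, with a different aryl group, also sits at a measurable number. On that basis a drop out of the limit is expected for compound 4 as well, of a size at least as large as the step to compound 3. Compound 4 is expected near 10000 nM, with a range of 2500 nM to 40000 nM. This corresponds to an expected at least 6.4-fold lower number from compound 1 to compound 4 (0.80 log units; beyond the scatter).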

Compound 4, half-maximal inhibitory concentration: 9290 nM
Beside the measured number, compound 4's estimate is 1.1-fold (0.03 log units) above it; low and high end bracket the measured number.
By their numbers in this assay, from the lowest: compound 2; then compounds 4 and 3 (each within the scatter of the next). At a limit, above all of these: compound 1.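

In this assay, 2-hydroxynaphthalen-1-yl in place of 4-chlorophenyl gives an at least 6.8-fold lower number from compound 1 to compound 4 (0.83 log units; beyond the scatter), so a group with two six-membered aromatic rings on this carbon still gives a measurable number. The true size of that step cannot be read, since compound 1 stands only at a limit: the limit of > 64000 nM in this assay, at which 1 of the 4 values shown sits.

With compound 3 and compound 4, two different hydroxy-bearing aryl groups now give measurable numbers here, but compound 2, which carries no hydroxy, goes against any reading that a hydroxy is required.

The compounds shown do not separate the contribution of the hydroxy from that of the second ring, and a plain naphthalen-1-yl group would bear directly on this. On these data alone, how an amine or a carboxylic acid in place of the hydroxy would read in this assay also remains open.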